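The compounds below may be only part of what the source reports. "The series", "measured", "known", "first", "only" and "open" are said of these compounds alone.

Working notes on the series. In a functional assay on HeLa cells (Homo sapiens) for antiproliferative activity, read by CCK-8 assay, with a stated time of 72 h (on this read-out higher numbers stand for weaker inhibition and lower numbers for stronger inhibition), compound 1 `COc1ccc(-c2cncnc2-c2cc(OC)c(OC)c(OC)c2)cc1` gives 1140 nM, compound 2 `CCSc1ccc(-c2cncnc2-c2cc(OC)c(OC)c(OC)c2)cc1` gives 370 nM and compound 3 `CCOc1ccc(-c2cncnc2-c2cc(OC)c(OC)c(OC)c2)cc1` gives 250 nM. Compound 3 has the lowest of these three numbers, but its gap to compound 2 lies within the scatter, a 1.5-fold lower number from compound 2 to compound 3 (0.17 log units; within the scatter). Only compound 1 stands clearly apart from it.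

The next compound, compound 4 `COc1cc(-c2ncncc2-c2ccc(OC(C)C)cc2)cc(OC)c1OC`, carries methyl in place of hydrogen on a saturated chain carbon bound to an oxygen on an aromatic ring and a saturated chain carbon; the same difference reads ethoxy to isopropoxy.

For the measured compounds named here, the closest precedent is a 4.6-fold lower number from compound 1 to compound 3 (0.66 log units; beyond the scatter), a modest step that also places a methyl on a saturated chain carbon bound to an oxygen on an aromatic ring. a 3.1-fold lower number from compound 1 to compound 2 (0.49 log units; beyond the scatter) is also modest, but it exchanges the whole group and says less about this change. Going by the values given here, no measured compound has a branched chain here, so one step is the only guide to direction in this assay. On that precedent, a small further move towards lower numbers is expected, smaller than the step to compound 3 and probably not beyond the scatter.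

The expected step is a 1.1-fold lower number from compound 3 to compound 4 (0.06 log units; within the scatter). For compound 4 the estimated value is 220 nM, with an expected range of 80 nM to 650 nM.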

Compound 4, half-maximal inhibitory concentration: 8360 nM
Estimate against measurement, compound 4: 38-fold (1.58 log units) below, and the stated range ends below it.
By their numbers in this assay, from the lowest: compounds 3 and 2 (each within the scatter of the next); then compound 1; then compound 4.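

In this assay the direction of the earlier methyl step does not carry over: adding a methyl to the saturated chain carbon bound to the oxygen gave a 4.6-fold lower number from compound 1 to compound 3 (0.66 log units; beyond the scatter) when that carbon was the methoxy carbon, but a 33-fold higher number from compound 3 to compound 4 (1.52 log units; beyond the scatter) when it was the ethoxy carbon that became branched. The isopropoxy group also stands clearly apart from ethylsulfanyl (a 23-fold higher number from compound 2 to compound 4 (1.35 log units; beyond the scatter)) and from methoxy (a 7.3-fold higher number from compound 1 to compound 4 (0.87 log units; beyond the scatter)), so compound 4 has the highest number of the four compounds and isopropoxy is the only group shown that ends above methoxy. At this position, then, the outcome of a methyl in place of hydrogen depends on the carbon that receives it, and the ethyl to isopropyl change is the largest step seen so far in the series; no data shown here bear on why this is so.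

The compounds shown leave open whether the high number follows from branching as such or from chain size, which an unbranched propoxy group would separate. They also leave open whether isopropylsulfanyl would show the same step from ethylsulfanyl.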